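This account rests on a few compounds, and the source may have more. Where it says the series, first, only, none or still open, it means among the compounds named here.

Three measured compounds share one core: compound 1 `COC(=O)NCC#CCn1cncc1C`, compound 2 `COC(=O)N(C)CC#CCn1cncc1C` and compound 3 `COC(=O)N(C)C(C)C#CCn1cncc1C`. In a functional assay on the whole organism for antagonist activity, with Mus musculus as the target (a lower number here means that less compound is needed, a higher number that more compound is needed for the effect), compound 1 gives 66 mg/kg, compound 2 gives 3 mg/kg and compound 3 gives 3.7 mg/kg. Compound 2 thus has the lowest of the three numbers, although compound 3 lies within the scatter of it, so the two cannot be ranked against each other. The measured steps are a 22-fold lower number from compound 1 to compound 2 (1.34 log units; beyond the scatter), a large change for methyl in place of hydrogen on an amide-type nitrogen, and a 1.2-fold higher number from compound 2 to compound 3 (0.09 log units; within the scatter), which stays within the scatter. Compound 4 `Cc1cncn1CC#CCN(C)C(=O)N(C)C` differs from compound 2 by dimethylamino in place of methoxy on a carbonyl carbon, a change at the methoxycarbonyl end that neither measured step touches. With nothing bearing directly on it, no change beyond the scatter is expected, and compound 4 is estimated at 4 mg/kg, between 1.5 mg/kg and 12 mg/kg. That estimate means a 1.3-fold higher number from compound 2 to compound 4 (0.12 log units; within the scatter), a step expected to stay within the scatter, with a range widened for the lack of a precedent.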

Compound 4, dose for half-maximal effect: 9.7 mg/kg
The estimate for compound 4 lay 2.4-fold (0.38 log units) below the measured number; the range from low to high includes it.
By their numbers in this assay, from the lowest: compounds 2 and 3 (each within the scatter of the next); then compound 4; then compound 1.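

The methoxycarbonyl end of compound 2, which neither earlier step touched, proves able to move the number in this assay (compound 4 against compound 2: a 3.2-fold higher number from compound 2 to compound 4 (0.51 log units; beyond the scatter)). Dimethylamino in place of methoxy on a carbonyl carbon is therefore a modest change but not a silent one, and the dimethylcarbamoyl compound still acts in the whole organism at a dose of the same order. Nothing measured here bears on why the number rises with this change.

From the compounds shown here alone, whether this step is particular to dimethylamino stays open, and an ethoxy group, a methylamino group or a pyrrolidine ring on the same carbonyl carbon would help to settle that. Also open, going by these compounds, is how the extra methyl on the chain carbon of compound 3 would behave alongside dimethylcarbamoyl.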